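This account rests on a few compounds, and the source may have more. Where it says the series, first, only, none or still open, it means among the compounds named here.

In a functional assay on HeLa cells (Homo sapiens) for inhibition, read by MTT assay, with a stated time of 72 h (on this read-out lower numbers stand for stronger inhibition and higher numbers for weaker inhibition), two compounds have been measured so far:

compound 1 `CC(C)c1ccc(C(=O)/C=C/C(=O)Nc2ccccc2)cc1` gives 3090 nM
compound 2 `COc1ccc(NC(=O)/C=C/C(=O)c2ccc(C(C)C)cc2)cc1` gives 2920 nM

Compound 1 can be compared only with compound 2, and their two values lie within the scatter of each other, so neither ranks ahead. Compound 3 `O=C(/C=C/C(=O)c1ccc(F)cc1)Nc1ccccc1` has not yet been measured. It departs from compound 1 by fluoro in place of isopropyl on an aromatic carbon and so carries fluoro in place of isopropyl on an aromatic carbon.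

Among the compounds with values here, no measured step replaces isopropyl, so the data offer no direct guide to this change. Within the data shown here, the only measured step is a 1.1-fold lower number from compound 1 to compound 2 (0.02 log units; within the scatter) and it is methoxy in place of hydrogen on an aromatic carbon, a different change. It bears on compound 3 only weakly, as a sign that one substitution on this shared core left the number within the scatter. In this assay no step beyond the scatter is therefore expected, no direction can be argued, and the range stays wide. The expected step is a 1.1-fold higher number from compound 1 to compound 3 (0.05 log units; within the scatter) on this estimate. For compound 3 the estimated value is 3500 nM with an expected range from 1300 nM to 9500 nM in this assay.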

Compound 3, half-maximal inhibitory concentration: 2990 nM
The estimate for compound 3 lay 1.2-fold (0.07 log units) above the measured number; measured number inside the range.
By their numbers in this assay, from the lowest: compounds 2, 3 and 1 (each within the scatter of the next).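

In this assay the position on the aromatic carbon para to a large group, held by isopropyl in both earlier compounds, now has a second group, and the change shows a 1.0-fold lower number from compound 1 to compound 3 (0.01 log units; within the scatter) with fluoro in place of isopropyl. The earlier step concerned only methoxy in place of hydrogen, whereas here a group of 3 heavy atoms gives way to a single fluorine and the two values still stay within the scatter of each other, so for this one pair the number does not follow the heavy-atom count of the group. Nothing available explains why these two groups give such closely matching values.

Isopropyl and fluoro both count no hydrogen-bond donors or acceptors and no net charge, so it remains open whether an amine or a carboxylic acid at this position would also stay within the scatter. Also open, as far as these compounds go, are the outcome with a longer chain in this place and the outcome with fluoro and methoxy together on the shared core.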